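Trading fluoro for trifluoromethyl on a cytotoxic compound

This account rests on a few compounds, and the source may have more. Where it says the series, first, only, none or still open, it means among the compounds named here.

Compound 1 `CN1C/C(=C\c2cccnc2)C(=O)/C(=C/c2ccccc2F)C1` is the starting point. In a functional assay on SMMC-7721 cells (Homo sapiens) for cytotoxicity, read by MTT assay, with a stated time of 24 h (on this read-out lower numbers stand for stronger inhibition and higher numbers for weaker inhibition), compound 1 gives 5420 nM. Under the same test, compound 2 `CN1C/C(=C\c2cccnc2)C(=O)/C(=C/c2cc([N+](=O)[O-])ccc2F)C1` gives 6170 nM and compound 3 `CN1C/C(=C\c2cccnc2)C(=O)/C(=C/c2ccc(F)cc2Br)C1` gives 20800 nM. Compound 1 therefore sits at the low end of these three numbers, level with compound 2 and clearly below compound 3.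

The unmeasured compound 4 `CN1C/C(=C\c2cccnc2)C(=O)/C(=C/c2ccccc2C(F)(F)F)C1` keeps the core of compound 1 and changes one group, with trifluoromethyl in place of fluoro on an aromatic carbon.

Two measured steps offer guidance, though neither makes this exact swap. Putting nitro in place of hydrogen on an aromatic carbon gave a 1.1-fold higher number from compound 1 to compound 2 (0.06 log units; within the scatter). Replacing 2-fluorophenyl with 2-bromo-4-fluorophenyl gave a 3.8-fold higher number from compound 1 to compound 3 (0.58 log units; beyond the scatter). This second step is the closer parallel, since it also enlarges what the ring carries in place of a simple fluoro pattern. On that basis, a modest rise in this assay is expected, although a result within the scatter would be no surprise.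

The expected change is a 1.7-fold higher number from compound 1 to compound 4 (0.22 log units; within the scatter). For compound 4 the estimated value is 9000 nM, with an expected range of 3500 nM to 23000 nM.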

Compound 4, half-maximal inhibitory concentration: 3900 nM
Compound 4: middle estimate off by 2.3-fold (0.36 log units), on the high side; the measured number falls inside the stated range.
By their numbers in this assay, from the lowest: compounds 4, 1 and 2 (each within the scatter of the next); then compound 3.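

In this assay, trifluoromethyl in place of fluoro gives a 1.4-fold lower number from compound 1 to compound 4 (0.14 log units; within the scatter), so a group of 4 heavy atoms can replace one of 1 heavy atom on this aromatic carbon, ortho to a large group, with no change that stands out from the scatter. The earlier step beyond the scatter, a 3.8-fold higher number from compound 1 to compound 3 (0.58 log units; beyond the scatter), exchanged the whole 2-fluorophenyl group for 2-bromo-4-fluorophenyl and so could not show how this one place responds to a larger group alone; the new step shows that a larger group here need not raise the number. No measurement is available to explain why the two compounds read alike.

The compounds shown leave open how a methoxy group, an amine or a carboxylic acid would read on this same aromatic carbon. They also leave open whether a plain hydrogen there would read like fluoro and trifluoromethyl, which would show whether this place needs any group at all.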